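A few compounds are considered here, and "the series" means these few. Any claim that something is new, unique, unknown or untested is made for them only; others in the source may bear on it.

Measured so far in an assay on CHO-K1 cells for antagonist activity at transient receptor potential cation channel subfamily V member 1 (Homo sapiens), read by FLIPR and calcium flux, with a stated time of 6 min; a higher number here means a weaker inhibitor, a lower number a stronger inhibitor:

- compound 1 `Cn1ncc2c(NC(=O)NCc3cc(C(F)(F)F)nn3-c3cccc(Cl)c3)cccc21` gives 2.3 nM
- compound 2 `Cn1ncc2c(NC(=O)NCc3cc(C(F)(F)F)nn3-c3cccc(F)c3)cccc21` gives 7 nM
- compound 3 `Cn1ncc2c(NC(=O)NCc3cc(C(C)(C)C)nn3-c3ccc(F)c(F)c3)cccc21` gives 1 nM

Within this set, compound 3 has the lowest number; its steps to compound 1 and compound 2 are both beyond the scatter. The change from compound 2 to compound 1 is chloro in place of fluoro on an aromatic carbon and gave a 3.0-fold lower number from compound 2 to compound 1 (0.48 log units; beyond the scatter). The cores of compound 3 and compound 2 differ, but that difference is not broken down here.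

Compound 4 `Cn1ncc2c(NC(=O)NCc3cc(C(C)(C)C)nn3-c3ccc(F)c(Cl)c3)cccc21` is not yet measured. It differs from compound 3 by chloro in place of fluoro on an aromatic carbon. The place is not identical to the earlier one: here the aromatic carbon is also ortho to a fluoro group, so this is the same kind of change, not the same change. Going by the values given here, a step of similar size is expected from compound 3 to compound 4 in this assay, namely a 2.0-fold lower number from compound 3 to compound 4 (0.30 log units; within the scatter), because the one precedent is a 3.0-fold lower number from compound 2 to compound 1 (0.48 log units; beyond the scatter). For compound 4 the estimate is 0.5 nM, with a range from 0.2 nM to 1.5 nM.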

Compound 4, inhibition constant: 0.6 nM
Beside the measured number, compound 4's estimate is 1.2-fold (0.08 log units) below it; measured number inside the range.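

In this assay, chloro in place of fluoro on an aromatic carbon gives a 1.7-fold lower number from compound 3 to compound 4 (0.22 log units; within the scatter), so on this core the change alone cannot be told from the usual scatter. Set beside the earlier case, the two steps cannot be told apart: the same change on two cores in this assay, a 3.0-fold lower number (0.48 log units; beyond the scatter) from compound 2 to compound 1 and a 1.7-fold lower number (0.22 log units; within the scatter) from compound 3 to compound 4, 1.8-fold (0.26 log units) apart, within the scatter of two such steps. This shows no detectable dependence on the core across these two pairs, but it does not fix the size of the change or show that it transfers generally, and in the second pair the aromatic carbon is also ortho to a fluoro group.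

Open, going by these compounds, is whether a bromo, methoxy or nitrile group on the same aromatic carbon would behave like chloro. Also open, on these data alone, is how the change behaves on a core carrying neither trifluoromethyl nor tert-butyl.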